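Ring swap at the chain end of compound 3

This account rests on a few compounds, and the source may have more. Where it says the series, first, only, none or still open, it means among the compounds named here.

Compound 3 `COc1cc2c(Nc3nc4ccc(C(=O)Nc5c(C)cccc5C)cc4s3)ncnc2cc1OCCCN1CCCC1` carries pyrrolidin-1-yl at the end of its propoxy chain, and in a functional assay on U-937 cells (Homo sapiens) for cytotoxicity, read by WST assay, with a stated time of 72 h (a higher number here means a weaker inhibitor, a lower number a stronger inhibitor), compound 3 gives 18900 nM, the highest number among the three measured compounds. Its nearest neighbour is compound 1 `COc1cc2c(Nc3nc4ccc(C(=O)Nc5c(C)cccc5C)cc4s3)ncnc2cc1OCCCN1CCC(C)CC1`, which in this assay gives 11200 nM; the step of a 1.7-fold higher number from compound 1 to compound 3 (0.23 log units; within the scatter) lies within the scatter. Going by the values given here, compound 2 `COc1cc2c(Nc3nc4ccc(C(=O)Nc5c(C)cc(C)cc5C)cc4s3)ncnc2cc1OCCCN1CCCCC1C` differs from compound 3 in two places, and no single step connects these two. In this assay, among the compounds with values here, compound 2 gives 3600 nM, a lower number than the one of compound 3, beyond the scatter.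

Compound 4 `COc1cc2c(Nc3nc4ccc(C(=O)Nc5c(C)cccc5C)cc4s3)ncnc2cc1OCCCN1CCCCC1C` has not yet been measured. Relative to compound 3 the change is 2-methylpiperidin-1-yl in place of pyrrolidin-1-yl on a saturated chain carbon, three bonds along the chain from an oxygen on an aromatic ring.

Within the data shown here, the only measured step that bears on this change is a 1.7-fold higher number from compound 1 to compound 3 (0.23 log units; within the scatter), which shows that exchanging a methylated piperidine for pyrrolidine at this position moves the number only within the scatter. Compound 2 shows a lower number with 2-methylpiperidin-1-yl present, but its amide differs as well, so its value cannot be assigned to the ring alone. Compound 4 is therefore expected to give a somewhat lower number than compound 3, a 2.4-fold lower number from compound 3 to compound 4 (0.37 log units; beyond the scatter), with an estimate of 8000 nM in this assay, between 3500 nM and 18000 nM.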

Compound 4, half-maximal inhibitory concentration: 10800 nM
The estimate for compound 4 lay 1.4-fold (0.13 log units) below the measured number, within the range that was stated.
By their numbers in this assay, from the lowest: compound 2; then compounds 4, 1 and 3 (each within the scatter of the next).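

In this assay the change to 2-methylpiperidin-1-yl, a 1.8-fold lower number from compound 3 to compound 4 (0.24 log units; within the scatter), stays within the scatter, and so does moving the methyl around the piperidine, a 1.0-fold lower number from compound 1 to compound 4 (0.02 log units; within the scatter). With this amide, therefore, pyrrolidin-1-yl, 4-methylpiperidin-1-yl and 2-methylpiperidin-1-yl at the end of the propoxy chain cannot be told apart in this cell read-out. Going by these compounds alone, the one new step beyond the scatter lies elsewhere in the molecule, a 3.0-fold higher number from compound 2 to compound 4 (0.48 log units; beyond the scatter), with hydrogen in place of methyl on an aromatic carbon, so the lower number of compound 2 goes with that methyl and not with the ring at the chain end.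

Still open, going by these compounds, is whether an open-chain amine such as diethylamino, a piperazin-1-yl ring or a chain longer than propoxy would move the number beyond the scatter, and whether the ring groups would still be indistinguishable with the extra aromatic methyl in place. Nothing among the data shown gives a reason for these results.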